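Chloro to methoxy on the aryl ring of a cyclic urea

The source may report more compounds than this note shows. Statements on the series, on what has been measured and on what is new or still open speak of the compounds shown alone.

Measured so far:
compound 1 `O=C1NCCN(c2cccc(F)c2)N1` gives 19000 nM
compound 2 `O=C1NCCN(c2cccc(Cl)c2)N1` gives 5300 nM

In an assay on RBL-1 cells for inhibition of Polyunsaturated fatty acid 5-lipoxygenase (Rattus norvegicus) (on this read-out higher numbers stand for weaker inhibition and lower numbers for stronger inhibition), compound 2 stands lowest of the two numbers; its nearest neighbour is compound 1, and the step of a 3.6-fold lower number from compound 1 to compound 2 (0.55 log units; beyond the scatter) lies beyond the scatter. Compound 3 `COc1cccc(N2CCNC(=O)N2)c1` carries methoxy in place of chloro on an aromatic carbon. Among the measured compounds shown here, the only measured step, a 3.6-fold lower number from compound 1 to compound 2 (0.55 log units; beyond the scatter), concerns one halogen for another and bears on this change only loosely, since methoxy is not a halogen. A modest rise in the number is therefore expected, a 1.7-fold higher number from compound 2 to compound 3 (0.23 log units; within the scatter). Compound 3 is estimated at 9000 nM, in the range 3000 nM to 30000 nM.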

Compound 3, half-maximal inhibitory concentration: 47000 nM
For compound 3 the middle estimate is 5.2-fold (0.72 log units) below the measured one, outside the stated range (above it).
By their numbers in this assay, from the lowest: compound 2; then compound 1; then compound 3.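

In this assay methoxy on this aromatic carbon raises the number, with an 8.9-fold higher number from compound 2 to compound 3 (0.95 log units; beyond the scatter) and with a 2.5-fold higher number from compound 1 to compound 3 (0.39 log units; beyond the scatter) as the comparison with fluoro, so it stands past both halogens rather than between them. The earlier compounds had shown only an exchange of one halogen for another, whereas methoxy, which brings one hydrogen-bond acceptor, gives the weakest inhibition of the three. Nothing measured here accounts for this result.

The compounds shown leave open how a hydroxy group, an amine or a longer ether chain such as ethoxy on this carbon would compare. They also leave open whether methoxy would keep this order on another carbon of the ring.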